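The source may hold more compounds than are shown below. What is called first, only, known or untested is meant among the compounds shown, and "the series" means these compounds.

Within the data shown here, compound 2 `O=S(=O)(NCCNC(=S)Nc1cccc(Cl)c1)c1ccc(-c2ccccc2OCc2ccccc2)s1` gives 8400 nM in a functional assay on HeLa cells (Homo sapiens) for inhibition, read by CCK-8 assay, with a stated time of 48 h (a higher number here means a weaker inhibitor, a lower number a stronger inhibitor), the only number in the set so far. Compound 1 `O=C(NCCNS(=O)(=O)c1cc(-c2ccccc2Oc2ccc(O)c(O)c2)cs1)Nc1cc(C(F)(F)F)cc(C(F)(F)F)c1` gives only a limit in this assay, > 20000 nM. Compound 3 `Cc1cc(C)cc(NC(=O)NCCNS(=O)(=O)c2ccc(-c3ccccc3OCc3ccccc3)s2)c1` has not been measured; it differs from compound 2 by a group of 11 heavy atoms (9 carbon, 1 nitrogen, 1 oxygen; one six-membered aromatic ring of carbon only) in place of a group of 10 heavy atoms (7 carbon, 1 nitrogen, 1 sulfur, 1 chlorine; one six-membered aromatic ring of carbon only), on an amine nitrogen. Among the measured compounds shown here, no pair of measured compounds differs in one place, so this step has no precedent. In this assay compound 3 is expected to move by a 1.2-fold higher number from compound 2 to compound 3 (0.08 log units; within the scatter), not clearly beyond the usual scatter. Compound 3 is estimated at 10000 nM, with a range from 3000 nM to 30000 nM.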

Compound 3, half-maximal inhibitory concentration: > 50000 nM
Compound 3 gave a limit, no number (the forecaster's own chance of this, stated with the estimate: 30%); at least 5.0-fold (0.69 log units) between middle value and limit.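

Placing (3,5-dimethylphenyl)carbamoyl on the amine nitrogen, in place of the group carrying sulfur and chlorine, gives an at least 5.9-fold higher number from compound 2 to compound 3 (0.77 log units; beyond the scatter) in this assay, the first sign in the series that this position responds to change. Compound 3 is a limit, not a number, so the step gives only a minimum size: the limit of > 50000 nM in this assay, at which 1 of the 3 values shown sits.

The change swaps sulfur for oxygen and chlorine for two methyl groups together, so the step cannot be assigned to either. A chlorophenylcarbamoyl group on the same nitrogen would separate the two. From the compounds shown here alone, how an amine or a carboxylic acid on that ring would read remains open.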